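From 4-Bromophenyl to 2-Chlorophenyl in a Cytotoxicity Series

The compounds below may be only part of what the source reports. "The series", "measured", "known", "first", "only" and "open" are said of these compounds alone.

In a functional assay on SW-620 cells (Homo sapiens) for cytotoxicity, read by MTT assay, with stated times of 4 h and 72 h, tested at 2 uM (on this read-out lower numbers stand for stronger inhibition and higher numbers for weaker inhibition), compound 1 (`Cc1cc(Nc2ccc(C(=O)/C=C/c3ccc(OC(F)(F)F)cc3)cc2)n2nc(SCc3nc4ccccc4[nH]3)nc2n1`) gives 220 nM and compound 2 (`Cc1cc(Nc2ccc(C(=O)/C=C/c3ccc(Br)cc3)cc2)n2nc(SCc3nc4ccccc4[nH]3)nc2n1`) gives 290 nM as its number, so compound 2 sits within the scatter of compound 1. Compound 3 (`Cc1cc(Nc2ccc(C(=O)/C=C/c3ccccc3Cl)cc2)n2nc(SCc3nc4ccccc4[nH]3)nc2n1`) differs from compound 2 by 2-chlorophenyl in place of 4-bromophenyl on a double-bonded chain carbon bound to a double-bonded chain carbon on a double-bonded chain carbon. For the measured compounds named here, the only measured step is a 1.3-fold higher number from compound 1 to compound 2 (0.12 log units; within the scatter) and it points to no large move, although it never tested a 2-chlorophenyl group. The expected change is a 1.2-fold higher number from compound 2 to compound 3 (0.08 log units; within the scatter) in this assay and so none beyond the scatter. The estimated value for compound 3 is 350 nM (range 130 nM to 900 nM).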

Compound 3, half-maximal inhibitory concentration: 680 nM
Beside the measured number, compound 3's estimate is 1.9-fold (0.29 log units) below it; the measured number falls inside the stated range.
By their numbers in this assay, from the lowest: compounds 1 and 2 (each within the scatter of the next); then compound 3.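

In this assay the group on this double-bonded chain carbon now makes a measurable difference: 2-chlorophenyl in place of 4-bromophenyl gives a 2.3-fold higher number from compound 2 to compound 3 (0.37 log units; beyond the scatter) and in place of 4-(trifluoromethoxy)phenyl gives a 3.1-fold higher number from compound 1 to compound 3 (0.49 log units; beyond the scatter) as its step. Both steps are modest but beyond the scatter, unlike the step between the two earlier groups. Nothing available explains this loss of potency.

This change swaps bromine for chlorine and also moves the halogen, so the two effects cannot be separated here; 4-chlorophenyl and 2-bromophenyl would separate them. Going by these compounds, how an amine or a carboxylic acid on this phenyl ring would behave remains open.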